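A few compounds are considered here, and "the series" means these few. Any claim that something is new, unique, unknown or untested is made for them only; others in the source may bear on it.

Measured in a functional assay on HL-60 cells (Homo sapiens) for inhibition, read by MTT assay, with a stated time of 48 h, tested at 10 uM; a higher number here means more inhibition of growth at the concentration tested, a lower number less inhibition of growth:
Compound 1 `COc1ccc(COc2cc(O)c3c(=O)cc(C)oc3c2[C@H]2CCN(C)C[C@H]2O)cc1`: 23%
Compound 2 `Cc1cc(=O)c2c(O)c(CN3CCCC3)c(O)c([C@H]3CCN(C)C[C@H]3O)c2o1`: 38%

Only these two compounds have been measured so far. Compound 2, at 38%, holds the higher of the two values. Compound 1 gives 23%, and that gap lies beyond the usual scatter of repeated measurements. The two compounds differ in more than one place, so their gap cannot be read as the effect of any single change.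

The next compound to be tested is compound 3 `Cc1cc(=O)c2c(O)c(CN(C(C)C)C(C)C)c(O)c([C@H]3CCN(C)C[C@H]3O)c2o1`. It keeps the core of compound 2 and carries diisopropylamino in place of pyrrolidin-1-yl on a saturated chain carbon bound to an aromatic carbon. For the measured compounds named here, no measured pair shows what a change of this kind does in this assay, and the direction cannot be told from the data. Going by the values given here, the only anchor is compound 2 at 38%, so the expectation stays close to that value. The expected change is a number 2 percentage points lower from compound 2 to compound 3 (within the scatter), a step not expected to go beyond the scatter in either direction. For compound 3 the estimated value is 36%, with an expected range of 18% to 55%.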

Compound 3, percent growth inhibition at one concentration: 21%
Compound 3: the middle estimate sits 15 percentage points above what was measured; low and high end bracket the measured number.
By their numbers in this assay, from the lowest: compounds 3 and 1 (each within the scatter of the next); then compound 2.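

In this assay, for the compounds shown here, this is the first comparison that isolates a single change, and it shows that the group on this saturated chain carbon bound to an aromatic carbon matters for growth inhibition at the concentration tested. Replacing pyrrolidin-1-yl with diisopropylamino gives a number 17 percentage points lower from compound 2 to compound 3 (beyond the scatter). The change replaces a five-membered non-aromatic ring with an open group of more heavy atoms, while the hydrogen-bond donor and acceptor counts and the absence of net charge stay the same, and no measurement shown here explains the loss.

This one pair cannot separate the loss of the ring from the increase in heavy atoms, and it cannot show whether the trend would hold for other amines at this place. Diethylamino would test an open group with fewer carbons than diisopropylamino, while piperidin-1-yl and morpholin-4-yl would show how a larger ring, or a ring with an oxygen atom, compares with the pyrrolidin-1-yl of compound 2.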